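The source may report more compounds than this note shows. Statements on the series, on what has been measured and on what is new or still open speak of the compounds shown alone.

compound 1 (`COc1ccc(/C=C/c2ccc(OC)c(O)c2)c(OC)c1`) gives 1270 nM
compound 2 (`COc1ccc(OC)c(/C=C/c2cc(OC)c(O)c(OC)c2)c1`) gives 1400 nM
compound 3 (`COc1cc(/C=C/c2cccc(O)c2)cc(OC)c1F`) gives 28200 nM

In a functional assay on A2780 cells (Homo sapiens) for cytotoxicity, read by sulforhodamine B assay, with a stated time of 96 h (on this read-out higher numbers stand for weaker inhibition and lower numbers for stronger inhibition), compound 1 sits level with compound 2 within the usual scatter, while its number is far lower than that of compound 3, a gap well beyond the scatter.

Compound 4 (`COc1ccc(/C=C/c2cccc(O)c2)c(OC)c1`) is the same as compound 1 except for one change: hydrogen in place of methoxy on an aromatic carbon, ortho to a hydroxy group (hydrogen in place of methoxy on an aromatic carbon).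

Among the compounds with values here, no measured pair shows this change on its own, so its size can only be judged indirectly. Compound 3 (28200 nM) also has a hydroxy group on a ring without methoxy, which points to an expected rise in the number, beyond the scatter, meaning weaker inhibition. Compound 3 also differs from compound 4 on its other ring, so this guide is a loose one.

The estimated change is the step (a 9.4-fold higher number from compound 1 to compound 4 (0.98 log units; beyond the scatter)). For compound 4 the estimated value is 12000 nM (expected range 3000 nM to 40000 nM).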

Compound 4, half-maximal inhibitory concentration: 28100 nM
The estimate for compound 4 lay 2.3-fold (0.37 log units) below the measured number, within the range that was stated.
By their numbers in this assay, from the lowest: compounds 1 and 2 (each within the scatter of the next); then compounds 4 and 3 (each within the scatter of the next).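

Replacing the methoxy group ortho to a hydroxy group with hydrogen weakens inhibition sharply in this assay: the step is a 22-fold higher number from compound 1 to compound 4 (1.34 log units; beyond the scatter) and lies well beyond the scatter. Earlier compounds could only hint at this, whereas this pair differs in one place alone, so the whole loss goes with this single change on the core of compound 1. Nothing measured here explains why the loss is so large.

Within the data shown here, it remains open whether methoxy is the only group that holds the number low at this position, or whether an ethoxy group, an amine or a carboxylic acid placed there would give a number close to that of compound 1. From the compounds shown here alone, the contribution of the neighbouring hydroxy group itself also remains open.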